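Ether chain variation in the series

The source may report more compounds than this note shows. Statements on the series, on what has been measured and on what is new or still open speak of the compounds shown alone.

Measured so far:
compound 1 `CC(C)CCCOc1cccc(O)c1C(=O)/C=C/c1ccc(O)cc1`, 11000 nM
compound 2 `CC(C)(C)CCOc1cccc(O)c1C(=O)/C=C/c1ccc(C(=O)O)cc1`, 2800 nM
compound 3 `O=C(/C=C/c1ccc(O)cc1)c1c(O)cccc1OCC1CCCC1`, 13000 nM

In an assay on THP-1 cells for inhibition of nuclear factor NF-kappa-B complex (Homo sapiens), with stated times of 2 h and 16 h (on this read-out higher numbers stand for weaker inhibition and lower numbers for stronger inhibition), compound 1 stands second highest of the three numbers; compound 3 lies nearest to it, compound 2 furthest. Compound 4 `O=C(/C=C/c1ccc(O)cc1)c1c(O)cccc1OCCC1CCCC1` carries cyclopentyl in place of isobutyl on a saturated chain carbon, two bonds along the chain from an oxygen on an aromatic ring. For the measured compounds named here, the one measured step that bears on this is a 1.2-fold higher number from compound 1 to compound 3 (0.07 log units; within the scatter), a ring in place of a branched chain at the carbon bound to the oxygen, which gave nothing beyond the scatter. Compound 2 differs from compound 1 in two places at once, so its lower number cannot be assigned to the chain alone. No step beyond the scatter is therefore expected in this assay. For compound 4 the estimate is 12000 nM, range 6000 nM to 25000 nM, meaning an expected step of a 1.1-fold higher number from compound 1 to compound 4 (0.04 log units; within the scatter).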

Compound 4, half-maximal inhibitory concentration: 18000 nM
Beside the measured number, compound 4's estimate is 1.5-fold (0.18 log units) below it; the measured number falls inside the stated range.
By their numbers in this assay, from the lowest: compound 2; then compounds 1, 3 and 4 (each within the scatter of the next).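

In this assay, the 2-cyclopentylethyl ether of compound 4 shows a 1.6-fold higher number from compound 1 to compound 4 (0.21 log units; within the scatter), and moving to it from the cyclopentylmethyl ether shows a 1.4-fold higher number from compound 3 to compound 4 (0.14 log units; within the scatter). Neither step lies beyond the scatter, so at this position a ring-bearing chain now reads the same as the branched chain with the ring set further from the oxygen on an aromatic ring, as well as with the ring on the carbon bound to that oxygen. Nothing at hand explains this result. From the compounds shown here alone, whether an amine or a carboxylic acid on the ether chain, or a longer chain, would give a step beyond the scatter remains open.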